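The source may report more compounds than this note shows. Statements on the series, on what has been measured and on what is new or still open speak of the compounds shown alone.

Compound 1 `O=C(Nc1ccc(O)c(-c2nc3ccccc3s2)c1)c1cc([N+](=O)[O-])ccc1Cl`: > 25000 nM
Compound 2 `Cc1ccc(-c2nc3ccccc3s2)cc1NC(=O)c1cc([N+](=O)[O-])c(N2CCCCC2)cc1Cl`: > 25000 nM

Both entries come from an ADME assay on Raji cells (Homo sapiens) for cytotoxicity, with a stated time of 72 h; a lower number here means that less compound is needed, a higher number that more compound is needed for the effect. Compound 2 gives > 25000 nM, which is a limit of the assay and not a number. Compound 2 therefore stands at the limit of > 25000 nM in this assay, at which 2 of the 2 values shown sit, so no exact figure is available as a starting point.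

Compound 3 `Cc1ccc(-c2nc3ccccc3s2)cc1NC(=O)c1cc([N+](=O)[O-])ccc1Cl` is still unmeasured. It differs from compound 2 in one place: hydrogen in place of piperidin-1-yl on an aromatic carbon. In words, hydrogen stands in place of piperidin-1-yl on an aromatic carbon, ortho to a nitro group, meta to a chloro group and para to a large group.

Going by the values given here, no measured step shows what this change does. Among the compounds with values here, the only guide is compound 1, which also has no piperidin-1-yl. Compound 1 gives > 25000 nM, again a limit.

In this assay, no step beyond the usual scatter is therefore expected, and compound 3 will most likely also be reported only as a limit. The expected change is a number no higher from compound 2 to compound 3 (the limit leaves the size open). For compound 3 the estimated value is 25000 nM, with an expected range from 10000 nM to 50000 nM.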

Compound 3, half-maximal effective concentration: > 14000 nM
Compound 3 gave a limit, no number; the forecaster's own chance of this, stated with the estimate: 80%; the middle value does not contradict the limit.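

In this assay compound 3 gives > 14000 nM, which is a limit of the assay and not a number. Compound 2 gives > 25000 nM, also a limit. The step between compound 2 and compound 3 therefore cannot be read. The compounds shown leave open whether hydrogen in place of piperidin-1-yl changes the half-maximal effective concentration at all.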